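Aryl sulfone series: meta halogen swap on the phenyl

The compounds below may be only part of what the source reports. "The series", "measured", "known", "first", "only" and "open" are said of these compounds alone.

Measured so far in a functional assay on HEK293 cells for inhibition of 5-hydroxytryptamine receptor 6 (Homo sapiens), read by cAMP accumulation; a lower number here means a stronger inhibitor, a higher number a weaker inhibitor:
compound 1 `CNc1nn2c(C)c(CN)c(C)nc2c1S(=O)(=O)c1cccc(Cl)c1` gives 0.55 nM
compound 2 `CNc1nn2c(C)c(CN(C)C)c(C)nc2c1S(=O)(=O)c1ccccc1` gives 0.708 nM
compound 3 `CNc1nn2c(C)c(CN(C)C)c(C)nc2c1S(=O)(=O)c1cccc(F)c1` gives 0.891 nM

Compound 3 gives the highest number of the three in this assay, yet its gaps to the other two are both within the scatter: compound 2 sits nearest, compound 1 furthest, and neither gap supports any ranking of the three.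

The next compound, compound 4 `CNc1nn2c(C)c(CN(C)C)c(C)nc2c1S(=O)(=O)c1cccc(Cl)c1`, differs from compound 3 by chloro in place of fluoro on an aromatic carbon. The measured step that bears on this position is a 1.3-fold higher number from compound 2 to compound 3 (0.10 log units; within the scatter), which shows that placing fluoro on this ring left the number unchanged beyond the scatter. Compound 1 carries the same chloro on the same ring but differs from compound 4 at the amine, so its value shows only that the 3-chlorophenyl is compatible with a number near the others.

Nothing measured here suggests that exchanging fluoro for chloro at this carbon would move the number beyond the scatter. The step is therefore expected to be small and of no reliable direction: a 1.3-fold lower number from compound 3 to compound 4 (0.10 log units; within the scatter). Compound 4 is estimated at 0.7 nM, with a range from 0.3 nM to 1.6 nM.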

Compound 4, inhibition constant: 0.417 nM
Compound 4: middle estimate off by 1.7-fold (0.22 log units), on the high side; low and high end bracket the measured number.
By their numbers in this assay, from the lowest: compounds 4, 1, 2 and 3 (each within the scatter of the next, the first and the last beyond it).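

Working notes on the halogen at this ring carbon: in this assay, exchanging the 3-fluorophenyl for the 3-chlorophenyl gives a 2.1-fold lower number from compound 3 to compound 4 (0.33 log units; beyond the scatter), a modest step and the only one in this set of compounds that lies beyond the scatter. Neither halogen separates from hydrogen on its own, with chloro giving a 1.7-fold lower number from compound 2 to compound 4 (0.23 log units; within the scatter) and fluoro giving a 1.3-fold higher number from compound 2 to compound 3 (0.10 log units; within the scatter), so the two halogens can be told apart from each other here, but neither can be told apart from the unsubstituted phenyl. With the 3-chlorophenyl held constant, the side-chain change gives a 1.3-fold lower number from compound 1 to compound 4 (0.12 log units; within the scatter), so dimethylamino and amino on that chain cannot be told apart in this pair.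

The compounds shown leave open whether bromo, methyl, methoxy or trifluoromethyl on the same carbon would stay within this narrow band of values, and whether a pyrrolidine or a longer chain in place of the dimethylamino group would do the same. No supporting information is available to account for the difference between fluoro and chloro at this carbon.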